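Series notes: methoxy added to the hydrazone aryl

The source may hold more compounds than are shown below. What is called first, only, known or untested is meant among the compounds shown, and "the series" means these compounds.

Compound 3 `O=C(CSc1nnc(-c2ccncc2)n1-c1ccccc1)N/N=C/c1ccccc1` is measured in a functional assay on MCF7 cells (Homo sapiens) for inhibition, read by MTT assay, with a stated time of 48 h; a lower number here means a stronger inhibitor, a higher number a weaker inhibitor; compound 3 gives 23600 nM. Compound 2 `Clc1ccccc1CSc1nnc(-c2ccncc2)n1-c1ccccc1` gives 18100 nM, and the two numbers sit within the scatter of each other, so no order between compound 2 and compound 3 is claimed. Compound 1 `Fc1ccccc1CSc1nnc(-c2ccncc2)n1-c1ccccc1` gives only a limit, > 50000 nM, as stated in the limit of > 50000 nM in this assay, at which 1 of the 3 values shown sits. Within the data shown here, the one measured step, an at least 2.7-fold lower number from compound 1 to compound 2 (0.44 log units; beyond the scatter), concerns a halogen swap on a benzyl ring and is the only step known.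

Compound 4 `COc1ccc(/C=N/NC(=O)CSc2nnc(-c3ccncc3)n2-c2ccccc2)cc1` differs from compound 3 by methoxy in place of hydrogen on an aromatic carbon. Among the measured compounds shown here, no measured step touches this aryl ring or a methoxy group, so the halogen step gives no direct guide. The expectation is therefore a step no larger than the scatter in this assay: from compound 3 to compound 4 the expected change is a 1.2-fold lower number from compound 3 to compound 4 (0.07 log units; within the scatter). Compound 4 is estimated at 20000 nM, with a range from 7000 nM to 60000 nM, the top of the range allowing that only a limit is returned.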

Compound 4, half-maximal inhibitory concentration: 23700 nM
Estimate against measurement, compound 4: 1.2-fold (0.07 log units) below; the range from low to high includes it.
By their numbers in this assay, from the lowest: compounds 2, 3 and 4 (each within the scatter of the next). At a limit, above all of these: compound 1.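

Methoxy in place of hydrogen on an aromatic carbon, para to a large group, gives a 1.0-fold higher number from compound 3 to compound 4 (0.00 log units; within the scatter) in this assay. Among these compounds, this is the first reading at the hydrazone aryl ring, and phenyl to 4-methoxyphenyl leaves the number within the scatter, so this single change opens no measurable gap at this position, unlike the halogen swap on the benzyl ring. Compound 1 remains the only compound at a limit: the limit of > 50000 nM in this assay, at which 1 of the 4 values shown sits.

One substituent cannot show whether this ring position responds to any change at all; an amine or a carboxylic acid in the same place would test that. On these data alone, compound 2 and compound 3 differ in more than one place, so what the hydrazone side chain contributes relative to the benzyl group also stays open.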